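What a cyclopropylmethyl group may do to compound 1

The source may report more compounds than this note shows. Statements on the series, on what has been measured and on what is new or still open speak of the compounds shown alone.

Liver enzymes can break down a compound before it has a chance to act, so chemists measure how much of it survives exposure to them. In an ADME assay on microsomes from liver (Homo sapiens) for metabolic stability, read by LC-MS, using NADPH, with a stated time of 60 min, tested at 0.1 uM (on this read-out lower numbers stand for a less stable compound and higher numbers for a more stable compound), compound 1 `Fc1ccc(Nc2cc3[nH]c(Nc4ccc(N5CCNCC5)cn4)nc3cn2)cc1C(F)(F)F` gives 92% and compound 2 `Fc1ccc(Nc2cc3[nH]c(Nc4cc(N5CCNCC5)ccn4)nc3cn2)cc1C(F)(F)F` gives 98%. These two values lie within the usual scatter of each other, so neither compound can be called the more stable one.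

Compound 3 `Fc1ccc(Nc2cc3[nH]c(Nc4ccc(N5CCN(CC6CC6)CC5)cn4)nc3cn2)cc1C(F)(F)F` carries cyclopropylmethyl in place of hydrogen on an amine nitrogen in a ring of compound 1, which turns piperazin-1-yl into 4-(cyclopropylmethyl)piperazin-1-yl: cyclopropylmethyl in place of hydrogen on an amine nitrogen in a ring. Among the measured compounds shown here, no measured pair of compounds shows what such a change does in this assay, so any forecast is loose. With compound 1 at 92%, little room is left for an upward move, and a downward move is the more likely outcome. The expected change is a number 12 percentage points lower from compound 1 to compound 3 (beyond the scatter), an estimate with wide uncertainty. For compound 3, the estimated value is 80%, with an expected range of 60% to 95%.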

Compound 3, percent of the compound remaining: 52%
The estimate for compound 3 lay 28 percentage points above the measured number; the measured number lies below the stated range.
By their numbers in this assay, from the lowest: compound 3; then compounds 1 and 2 (each within the scatter of the next).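

In this assay, cyclopropylmethyl in place of hydrogen on the amine nitrogen of the piperazin-1-yl ring gives a number 40 percentage points lower from compound 1 to compound 3 (beyond the scatter), which marks this nitrogen as a place where one small addition can greatly alter how much compound survives. Compounds 1 and 2 could not show this, since their values lie within the scatter of each other and both carry hydrogen on that nitrogen. Compound 3 now shows that the high value of compound 1 does not hold for every group placed there, although the data offer no measurement that explains the fall.

As far as these compounds go, it remains open whether the loss belongs to cyclopropylmethyl itself or would also come with other groups on this nitrogen, such as a small methyl, a longer straight carbon chain or an acetyl group with its carbonyl. From the compounds shown here alone, it also remains open whether the same addition would have a similar effect on compound 2, where the piperazin-1-yl group sits at a different place on its ring.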